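Compound 3 to compound 4: methyl in place of fluoro

A few compounds are considered here, and "the series" means these few. Any claim that something is new, unique, unknown or untested is made for them only; others in the source may bear on it.

In a functional assay on A549 cells (Homo sapiens) for antiproliferative activity, read by sulforhodamine B assay, with a stated time of 72 h (on this read-out lower numbers stand for stronger inhibition and higher numbers for weaker inhibition), compound 1 `COc1cc2occ(-c3csc4ccccc34)c(=O)c2c(OC)c1O` gives > 10000 nM, which is a limit of the assay. Compound 2 `COc1c(OC(C)C)cc2ccc(-c3cc(=O)c4ccccc4o3)cc2c1OC(C)C` gives > 10000 nM, again a limit. Within the data shown here, the series so far is dominated by the limit of > 10000 nM in this assay, at which 2 of the 3 values shown sit. Among the measured compounds shown here, compound 3 `O=C(/C=C/c1csc2ccccc12)c1cc(F)ccc1O` gives 7100 nM, the only actual number available in this assay.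

Compound 4 `Cc1ccc(O)c(C(=O)/C=C/c2csc3ccccc23)c1` carries methyl in place of fluoro on an aromatic carbon, para to a hydroxy group: methyl in place of fluoro on an aromatic carbon. For the measured compounds named here, no measured pair tests this change, so the expectation rests on compound 3 at 7100 nM alone. The estimated 1.0-fold lower number from compound 3 to compound 4 (0.01 log units; within the scatter) stays within the scatter, with no direction expected. For compound 4 the expected value is 7000 nM, with an estimated range of 2800 nM to 14000 nM.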

Compound 4, half-maximal inhibitory concentration: 4800 nM
The estimate for compound 4 lay 1.5-fold (0.16 log units) above the measured number; low and high end bracket the measured number.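

In this assay, among these compounds, the first step between compounds differing in one place reads a 1.5-fold lower number from compound 3 to compound 4 (0.17 log units; within the scatter), so at this position, para to a hydroxy group, methyl and fluoro are not distinguished. Compound 4 also adds a second actual number to a series otherwise marked by a limit. Actual numbers remain few: the limit of > 10000 nM in this assay, at which 2 of the 4 values shown sit.

Open, on these data alone, is whether an amine, a carboxylic acid or a longer chain on this aromatic carbon would shift the number beyond the scatter. As far as these compounds go, whether the hydroxy group itself matters also remains open.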